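Swapping thiophene for pyridine on the shared core

The compounds below may be only part of what the source reports. "The series", "measured", "known", "first", "only" and "open" are said of these compounds alone.

Compound 1 `O=C1Nc2c(ccc(F)c2F)C1(c1ccc(O)cc1)c1ccc(F)cc1`: 2.6 nM
Compound 2 `COc1ccc(C2(c3ccc(O)cc3)C(=O)Nc3c2ccc(F)c3F)cc1`: 2.1 nM; 6.3 nM; > 1000 nM (3 entries) (separate entries for compound 2, which give no single number)
Compound 3 `O=C1Nc2c(ccc(F)c2F)C1(c1ccc(O)cc1)c1cccs1`: 82 nM

In a functional assay on MCF7 cells (Homo sapiens) for cytotoxicity, read by WST assay, with a stated time of 72 h (on this read-out lower numbers stand for stronger inhibition and higher numbers for weaker inhibition), compound 3 gives 82 nM, the higher of the two compounds with a single number. Compound 4 `O=C1Nc2c(ccc(F)c2F)C1(c1ccc(O)cc1)c1cccnc1` changes the same group: pyridin-3-yl in place of thiophen-2-yl on a saturated ring carbon. Within the data shown here, no measured step covers this swap directly. The nearest is a 32-fold higher number from compound 1 to compound 3 (1.50 log units; beyond the scatter), a large step showing that the group on this saturated ring carbon can shift the number strongly. A further rise in this assay, smaller than that step and with wide uncertainty, is therefore expected. The expected change is a 2.4-fold higher number from compound 3 to compound 4 (0.39 log units; beyond the scatter). For compound 4 the estimated value is 200 nM, within an expected range of 30 nM to 1300 nM.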

Compound 4, half-maximal inhibitory concentration: 63 nM
Beside the measured number, compound 4's estimate is 3.2-fold (0.50 log units) above it, and the stated range covers the measured number.
By their numbers in this assay, from the lowest: compound 1; then compounds 4 and 3 (each within the scatter of the next).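

Pyridin-3-yl in place of thiophen-2-yl gives a 1.3-fold lower number from compound 3 to compound 4 (0.11 log units; within the scatter) and so, in this assay, these two rings, one five-membered and one six-membered, cannot be told apart on this saturated ring carbon. Pyridin-3-yl in place of 4-fluorophenyl gives a 24-fold higher number from compound 1 to compound 4 (1.38 log units; beyond the scatter) and so shows that the large rise seen with thiophen-2-yl recurs with a second ring holding a hetero atom. Nothing shown here explains that rise. The compounds shown leave open how a longer chain or an amine on this carbon would read.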